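An imidazole chain in place of the pyrrole chain

The compounds below may be only part of what the source reports. "The series", "measured", "known", "first", "only" and "open" are said of these compounds alone.

The three measured compounds share the core of compound 1 `Cn1cc(C2=C(c3nn(CCCn4cccc4)c4ncccc34)C(=O)N(c3ccccc3)C2=O)c2ccccc21` and were tested in a functional assay on ECa-109 cells (Homo sapiens) for antiproliferative activity, read by MTT assay, with a stated time of 48 h; on this read-out higher numbers stand for weaker inhibition and lower numbers for stronger inhibition. Compound 1 gives only a limit of the assay, > 100000 nM. Compound 3 `Cn1cc(C2=C(c3nn(CCCn4cccc4)c4ncccc34)C(=O)NC2=O)c2ccccc21`, which carries hydrogen in place of phenyl on an amide-type nitrogen in a ring, likewise gives only a limit, > 100000 nM. The step that the two limits leave unreadable from compound 1 to compound 3 therefore remains unreadable. For the measured compounds named here, compound 2 `Cn1cc(C2=C(c3nn(CCCN4CCCCC4)c4ncccc34)C(=O)N(c3ccccn3)C2=O)c2ccccc21` is the one member with a number, 7300 nM. It differs from compound 1 in two places at once, so its comparison with compound 1 shows only what the two values themselves show. Compound 1 thus stands at the limit of > 100000 nM in this assay, at which 2 of the 3 values shown sit.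

Compound 4 `Cn1cc(C2=C(c3nn(CCn4ccnc4)c4ncccc34)C(=O)N(c3ccccc3)C2=O)c2ccccc21` is the unmeasured member. It differs from compound 1 by 1H-imidazol-1-yl in place of (1H-pyrrol-1-yl)methyl on a saturated chain carbon, two bonds along the chain from an aromatic nitrogen. No measured step bears on this part of the chain, and no size or direction can be read from the pairs shown. The expectation for compound 4 can only lean on compound 1 standing at a limit, > 100000 nM. Compound 4 is therefore expected to give a weak result near that limit, with the step of an at least 1.6-fold lower number from compound 1 to compound 4 (0.22 log units; that floor lies within the scatter) estimated as small and uncertain. The estimate for compound 4 in this assay is 60000 nM, expected to fall between 12000 nM and 300000 nM.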

Compound 4, half-maximal inhibitory concentration: 8770 nM
The estimate for compound 4 lay 6.8-fold (0.84 log units) above the measured number, outside the stated range (below it).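

In this assay, putting 1H-imidazol-1-yl in place of (1H-pyrrol-1-yl)methyl on a saturated chain carbon, two bonds along the chain from an aromatic nitrogen, gives an at least 11-fold lower number from compound 1 to compound 4 (1.05 log units; beyond the scatter). This is the first single change among these compounds with a readable effect: the step from compound 1 to compound 3, at the amide-type nitrogen, cannot be read, whereas this part of the chain responds clearly to change on the same core. The step is a floor and not a full size, since compound 1 stands at a limit of the assay: the limit of > 100000 nM in this assay, at which 2 of the 4 values shown sit.

Read one bond further out, the same difference runs from 3-(1H-pyrrol-1-yl)propyl to 2-(1H-imidazol-1-yl)ethyl, so the chain and the ring change together, and the compounds shown leave open which of the two carries the step. A 3-(1H-imidazol-1-yl)propyl chain and a 2-(1H-pyrrol-1-yl)ethyl chain would separate them, while a dimethylamine or a carboxylic acid at the chain end would show how far this position tolerates groups other than a five-membered aromatic ring.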